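The compounds below may be only part of what the source reports. "The series", "measured", "known", "first", "only" and "open" are said of these compounds alone.

Working notes on the ester series. In an ADME assay on a cell-free system (plasma, Homo sapiens) for metabolic stability, with Plasma (Rattus norvegicus) as the target, read by HPLC, at pH 7.4 (a higher number here means that the compound lasts longer, a lower number that the compound disappears faster), compound 1 `CC(=O)Oc1ccccc1C(=O)O[C@H]1CO[C@H]2[C@@H]1OC[C@H]2OC(=O)c1ccnn1C` gives 0.0963 h; compound 2 `CCCCC(=O)O[C@@H]1CO[C@H]2[C@@H]1OC[C@@H]2OC(=O)c1ccccc1OC(C)=O` gives 0.0198 h; compound 3 `COc1cccc(C(=O)O[C@@H]2CO[C@H]3[C@@H]2OC[C@@H]3OC(=O)c2ccccc2OC(C)=O)c1` gives 0.0525 h. Compound 3 thus stands second highest of the three numbers; the two steps that reach it are a 1.8-fold lower number from compound 1 to compound 3 (0.26 log units; within the scatter) and a 2.7-fold higher number from compound 2 to compound 3 (0.42 log units; beyond the scatter). Compound 4 `CC(=O)Oc1ccccc1C(=O)O[C@H]1CO[C@H]2[C@@H]1OC[C@H]2OC(=O)CCO[N+](=O)[O-]` differs from compound 3 by 2-(nitrooxy)ethyl in place of 3-methoxyphenyl on a carbonyl carbon. The precedents for a chain standing in place of a ring on that carbonyl carbon are a 4.9-fold lower number from compound 1 to compound 2 (0.69 log units; beyond the scatter) and a 2.7-fold higher number from compound 2 to compound 3 (0.42 log units; beyond the scatter), both modest and beyond the scatter, both with the chain on the lower side. A modest decrease in this assay is therefore expected, roughly reversing the last step. Compound 4 is estimated at 0.025 h, range 0.01 h to 0.06 h. The expected step is a 2.1-fold lower number from compound 3 to compound 4 (0.32 log units; beyond the scatter).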

Compound 4, half-life: 0.065 h
Compound 4: the middle estimate sits 2.6-fold (0.41 log units) below what was measured; measured number outside the range, above it.
By their numbers in this assay, from the lowest: compound 2; then compounds 3, 4 and 1 (each within the scatter of the next).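

On the carbonyl carbon, a chain does not of itself give the lower number in this assay: 2-(nitrooxy)ethyl stays level with both rings, 3-methoxyphenyl (a 1.2-fold higher number from compound 3 to compound 4 (0.09 log units; within the scatter)) and 1-methyl-1H-pyrazol-5-yl (a 1.5-fold lower number from compound 1 to compound 4 (0.17 log units; within the scatter)). Butyl alone stands apart, since nitrooxy in place of ethyl gives a 3.3-fold higher number from compound 2 to compound 4 (0.52 log units; beyond the scatter). No measurement at hand explains the gap between these two chains. As far as these compounds go, whether it follows the nitrooxy group or would persist with another chain end stays open. An amine or a carboxylic acid at that chain end, or a longer chain carrying nitrooxy, remains to be placed.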